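A few compounds are considered here, and "the series" means these few. Any claim that something is new, unique, unknown or untested is made for them only; others in the source may bear on it.

Within the data shown here, in a functional assay on HCT-116 cells (Homo sapiens) for antiproliferative activity, read by MTT assay, with a stated time of 72 h (on this read-out higher numbers stand for weaker inhibition and lower numbers for stronger inhibition), compound 1 (`O=C(CCc1cccc2c1B(O)OC2)Nc1cccc(-c2ccc(Cl)cc2)c1`) gives 380 nM and compound 2 (`O=C(CCc1cccc2c1B(O)OC2)Nc1cccc(-c2ccc(C(F)(F)F)cc2)c1`) gives 550 nM, so compound 2 stands within the scatter of the only other measured compound. Compound 3 (`N#Cc1cccc(-c2cccc(NC(=O)CCc3cccc4c3B(O)OC4)c2)c1`) carries 3-cyanophenyl in place of 4-(trifluoromethyl)phenyl on an aromatic carbon. Among the measured compounds shown here, the one measured step, a 1.4-fold higher number from compound 1 to compound 2 (0.16 log units; within the scatter), lies within the scatter, and no measured compound carries a nitrile, so this guide is thin. No change beyond the scatter is expected in this assay. The estimated step is a 1.1-fold higher number from compound 2 to compound 3 (0.04 log units; within the scatter). For compound 3 the expected value is 600 nM, with a range of 200 nM to 1800 nM.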

Compound 3, half-maximal inhibitory concentration: 140 nM
For compound 3 the middle estimate is 4.3-fold (0.63 log units) above the measured one; measured number outside the range, below it.
By their numbers in this assay, from the lowest: compound 3; then compounds 1 and 2 (each within the scatter of the next).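

In this assay, 3-cyanophenyl in place of 4-(trifluoromethyl)phenyl gives a 3.9-fold lower number from compound 2 to compound 3 (0.59 log units; beyond the scatter), and in place of 4-chlorophenyl it gives a 2.7-fold lower number from compound 1 to compound 3 (0.43 log units; beyond the scatter), so changes at this position can move the read-out beyond the scatter, which the earlier pair did not show. Each step changes both the group and where it sits on the ring, so the two effects cannot be separated. No available evidence explains the shift. From the compounds shown here alone, it remains open whether 4-cyanophenyl would match compound 3, and how an amine or a carboxylic acid would fare on this ring.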